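The compounds below may be only part of what the source reports. "The series", "measured", "known", "first", "only" and "open" are said of these compounds alone.

Measured compounds:
- compound 1, `Clc1ccc2[nH]c(SCc3ccccc3OCc3ccccc3)nc2c1`, 3%
- compound 2, `c1ccc(CCc2ccccc2CSc2ncc[nH]2)cc1`, 19%
- compound 3, `c1ccc(CCc2ccccc2CSC2=NCCS2)cc1`, 0%

The three compounds were tested in an assay on isolated protein for inhibition of Indoleamine 2,3-dioxygenase 1 (Homo sapiens), with a stated time of 60 min, tested at 10 uM; on this read-out lower numbers stand for less inhibition and higher numbers for more inhibition at the one concentration tested (going by the name of the read-out). Compound 2 gives 19%, the highest of the three numbers. Compound 1 stands second on these numbers, but its reading lies within the scatter of compound 3, so the two cannot be told apart; compound 2 sits beyond the scatter above compound 1. Among the compounds with values here, the one step that can be followed between measured compounds is a number 19 percentage points lower from compound 2 to compound 3 (beyond the scatter), a change of the heterocycle attached to the sulfur.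

The compound not yet measured is compound 4, `Clc1ccc2[nH]c(SCc3ccccc3C#Cc3ccccc3)nc2c1`. It differs from compound 1 in one place: 2-phenylethynyl in place of benzyloxy on an aromatic carbon. Within the data shown here, no measured pair shows this kind of change; the step from compound 2 to compound 3 concerns a different part of the molecule and gives no guidance here. The only anchor is the low reading of compound 1 itself.

Among the measured compounds shown here, with no directly relevant step and a low starting point, compound 4 is expected to stay near compound 1, with a step of a number 5 percentage points higher from compound 1 to compound 4 (within the scatter), not expected to exceed the scatter. The estimate for compound 4 in this assay is 8%, with a range from 0% to 25%.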

Compound 4, a percentage reported as inhibition, at one concentration (the size of the read-out at that concentration, not a potency): 52%
For compound 4 the middle estimate is 44 percentage points below the measured one; the measured number lies above the stated range.
By their numbers in this assay, from the lowest: compounds 3 and 1 (each within the scatter of the next); then compound 2; then compound 4.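

In this assay, the aromatic carbon ortho to a large group proves to be a place where the choice of substituent matters: on the core of compound 1, putting 2-phenylethynyl in place of benzyloxy gives a number 49 percentage points higher from compound 1 to compound 4 (beyond the scatter) and is the first change among these compounds to reach a clearly higher reading at this part of the molecule. The two groups have the same count of heavy atoms and each carries one six-membered aromatic ring of carbon only, so the heavy-atom count and the ring alone do not set the reading; what differs is that the oxygen and its hydrogen-bond acceptor leave and a triple bond outside aromatic rings enters. Nothing measured here explains the size of this step.

The compounds shown do not separate the loss of the oxygen from the gain of the triple bond, and no compound holds one without the other. Also open, from the compounds shown here alone, is how the reading would respond to an amine or a carboxylic acid on the outer ring of the 2-phenylethynyl group, or to a longer chain in its place.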